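Phenethyl in place of the fluorinated branch

The source may hold more compounds than are shown below. What is called first, only, known or untested is meant among the compounds shown, and "the series" means these compounds.

The three measured compounds share one urea core and differ in the side chain. Compound 1 `CC(C)(C)CCc1cc(C(F)(F)F)ccc1CNC(=O)Nc1cccc2[nH]ncc12` gives 4.3 nM in a functional assay for antagonist activity at transient receptor potential cation channel subfamily V member 1 (Homo sapiens); a higher number here means a weaker inhibitor, a lower number a stronger inhibitor. Compound 2 `CC(C)(C)COc1nc(C(F)(F)F)ccc1CNC(=O)Nc1cccc2[nH]ncc12` gives 6 nM in this assay, and compound 3 `CC(C)(F)CCc1cc(C(F)(F)F)ccc1CNC(=O)Nc1cccc2[nH]ncc12` gives 6 nM in this assay. Compound 3 stands level with compound 2 at the digits shown, the two together the highest of the three numbers, with compound 1 the furthest and still within the scatter, so all three sit together. Compound 4 `O=C(NCc1ccc(C(F)(F)F)cc1CCc1ccccc1)Nc1cccc2[nH]ncc12` has not yet been measured. The change is phenyl in place of 1-fluoro-1-methylethyl on a saturated chain carbon, two bonds along the chain from an aromatic carbon. Among the compounds with values here, only one measured step touches this chain carbon, a 1.4-fold higher number from compound 1 to compound 3 (0.14 log units; within the scatter), and it exchanges a single substituent there rather than the whole branch for a ring. Within the data shown here, no measured step introduces a phenyl in this place, so the direction is open. Because a 1.4-fold higher number from compound 1 to compound 3 (0.14 log units; within the scatter) stayed within the scatter, the step of a 1.7-fold higher number from compound 3 to compound 4 (0.22 log units; within the scatter) is expected to be small. Compound 4 is estimated at 10 nM in this assay, within 3 nM to 40 nM.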

Compound 4, half-maximal inhibitory concentration: 8 nM
The estimate for compound 4 lay 1.3-fold (0.10 log units) above the measured number; the measured number falls inside the stated range.
By their numbers in this assay, from the lowest: compounds 1, 2, 3 and 4 (each within the scatter of the next).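

At the saturated chain carbon two bonds along the chain from an aromatic carbon, the end of the side chain can now be an aromatic ring without leaving the scatter in this assay: phenyl in place of 1-fluoro-1-methylethyl gives (a 1.3-fold higher number from compound 3 to compound 4 (0.12 log units; within the scatter)), and phenyl in place of tert-butyl gives (a 1.9-fold higher number from compound 1 to compound 4 (0.27 log units; within the scatter)). The earlier step exchanged only a single substituent on the branch, whereas these two replace the whole branch, so this place accepts both branched saturated and phenyl ends in the compounds shown. No available evidence accounts for this result.

Still open, from the compounds shown here alone, is how far this acceptance extends: whether a chloro-substituted phenyl or a cyclohexyl ring behaves like phenyl here. Also open, going by these compounds, is whether an amine or a carboxylic acid at the chain end, or a longer chain carrying the phenyl, stays within the scatter.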